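The compounds below may be only part of what the source reports. "The series", "measured", "known", "first", "only" and "open" are said of these compounds alone.

Three compounds share one core: compound 1 `N#CN/C(=N\CCOC(=O)c1ccccc1)NCCCOc1cccc(CN2CCCCC2)c1`, compound 2 `N#CN/C(=N\CCNc1ccc(N=[N+]=[N-])cc1[N+](=O)[O-])NCCCOc1cccc(CN2CCCCC2)c1` and compound 3 `N#CN/C(=N\CCCCNC(=O)c1ccccc1)NCCCOc1cccc(CN2CCCCC2)c1`. In a functional assay on cardiac atrium for antagonist activity at histamine H2 receptor (Cavia porcellus) (on this read-out higher numbers stand for higher potency (the scale is a negative logarithm) and lower numbers for lower potency), compound 1 gives 7.64, compound 2 gives 7.39 and compound 3 gives 6.81, the lowest of the three numbers, with both neighbours beyond the scatter above it. Among the measured compounds shown here, the single one-point step among them is a number 0.83 log units lower from compound 1 to compound 3 (beyond the scatter). Compound 4 `Cc1ccc(S(=O)(=O)NCC/N=C(\NC#N)NCCCOc2cccc(CN3CCCCC3)c2)cc1` differs from compound 3 by ((4-methylphenyl)sulfonyl)amino in place of 2-benzamidoethyl on a saturated chain carbon, two bonds along the chain from a double-bonded nitrogen. For the measured compounds named here, no measured step carries this same change, so only that earlier step bears on it, and loosely: it shows that a group held on the carbon two bonds from the double-bonded nitrogen, as in compound 1, went with a higher number than the longer chain of compound 3. The expected step is therefore a modest rise, a number 0.39 log units higher from compound 3 to compound 4 (beyond the scatter). Compound 4 is estimated at 7.2, between 6.6 and 7.8.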

Compound 4, negative logarithm of the antagonist equilibrium constant: 6.13
The estimate for compound 4 lay 1.07 log units above the measured number; the measured number lies below the stated range.
By their numbers in this assay, from the lowest: compound 4; then compound 3; then compounds 2 and 1 (each within the scatter of the next).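

In this assay, ((4-methylphenyl)sulfonyl)amino on a saturated chain carbon, two bonds along the chain from a double-bonded nitrogen, gives a number 1.51 log units lower from compound 1 to compound 4 (beyond the scatter) in place of benzoyloxy and a number 0.68 log units lower from compound 3 to compound 4 (beyond the scatter) in place of 2-benzamidoethyl, so a group held at this place does not by itself go with a higher number. Likewise, (4-methylphenyl)sulfonyl in place of 4-azido-2-nitrophenyl on an amine nitrogen gives a number 1.26 log units lower from compound 2 to compound 4 (beyond the scatter). No measurement shown accounts for these falls.

Still open, as far as these compounds go, is how a free amine or a carboxylic acid would fare at this place. Also open, from the compounds shown here alone, is whether a longer chain carrying the ((4-methylphenyl)sulfonyl)amino group would change the number.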